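Losing the Aromatic Bicycle: What Compound 3 Might Give

The source may hold more compounds than are shown below. What is called first, only, known or untested is meant among the compounds shown, and "the series" means these compounds.

Compound 1 `COc1ccc2nccc(C3CN(C4CCN(Cc5cc6ccccc6s5)CC4)C(=O)O3)c2c1` — 794 nM
Compound 2 `COc1ccc2nccc(C3CN(C4CCN(Cc5ccc6ccccc6c5)CC4)C(=O)O3)c2c1` — 1260 nM

In an in vitro functional assay on RBL cells for antagonist activity at C-C chemokine receptor type 8 (Homo sapiens), read by FLIPR and calcium flux (on this read-out higher numbers stand for weaker inhibition and lower numbers for stronger inhibition), compound 2 gives 1260 nM, the highest of the two numbers. Compound 1 gives 794 nM, and the step of a 1.6-fold higher number from compound 1 to compound 2 (0.20 log units; within the scatter) stays within the scatter. Compound 3 `COc1ccc2nccc(C3CN(C4CCN(CC5CCCCC5)CC4)C(=O)O3)c2c1` carries cyclohexyl in place of naphthalen-2-yl on a saturated chain carbon bound to an amine nitrogen in a ring. For the measured compounds named here, the only measured step, from compound 1 to compound 2, exchanged one aromatic bicycle for another and was small; here both aromatic rings leave entirely, a change no measured pair covers, so the expectation is wide and leans toward weaker inhibition. Compound 3 is expected to give 3200 nM (range 800 nM to 15000 nM), a step of a 2.5-fold higher number from compound 2 to compound 3 (0.40 log units; beyond the scatter).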

Compound 3, half-maximal inhibitory concentration: 7940 nM
Beside the measured number, compound 3's estimate is 2.5-fold (0.39 log units) below it; the range from low to high includes it.
By their numbers in this assay, from the lowest: compounds 1 and 2 (each within the scatter of the next); then compound 3.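

At this position, the two bicyclic aromatic groups sit within the scatter of each other, but cyclohexyl does not match either in this assay: replacing naphthalen-2-yl gives (a 6.3-fold higher number from compound 2 to compound 3 (0.80 log units; beyond the scatter)) and replacing 1-benzothiophen-2-yl gives (a 10-fold higher number from compound 1 to compound 3 (1.00 log units; beyond the scatter)). The change removes both aromatic rings and also reduces the group from 10 heavy atoms to 6, so these compounds cannot separate the two differences. No evidence is available to explain the result.

A single phenyl ring would have aromatic character with the same count of six ring atoms as cyclohexyl. Going by these compounds, how it would compare with compound 1, compound 2 and compound 3 remains open.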